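Removing a Ring Methyl on the Pyrrolidine Side Chain

This account rests on a few compounds, and the source may have more. Where it says the series, first, only, none or still open, it means among the compounds named here.

Of the compounds shown here, three sharing one core have been tested in a functional assay on MCF7 cells (Homo sapiens) for antiproliferative activity, read by CellTiter-Glo, with a stated time of 5 days; on this read-out lower numbers stand for stronger inhibition and higher numbers for weaker inhibition. Compound 1 `CC1=C(c2ccc(O)cc2)C(c2ccc(OC[C@H](C)N3CC[C@@H](C)C3)cc2)Oc2cc(O)ccc21` gives 0.2 nM. Compound 2 `CC1=C(c2cccc(F)c2)C(c2ccc(OC[C@H](C)N3CC[C@@H](C)C3)cc2)Oc2ccc(O)cc21` gives 1 nM. For the measured compounds named here, compound 3 `CC1=C(c2cccc(O)c2)C(c2ccc(OC[C@H](C)N3CC[C@@H](C)C3)cc2)Oc2ccc(O)cc21` gives 0.2 nM, which sits level with compound 1 at the digits printed, the two together giving the lowest numbers of the three; the only counted step, a 5.0-fold lower number from compound 2 to compound 3 (0.70 log units; beyond the scatter), came from putting hydroxy in place of fluoro on an aromatic carbon.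

Compound 4 `CC1=C(c2cccc(O)c2)C(c2ccc(OC[C@H](C)N3CCCC3)cc2)Oc2ccc(O)cc21` differs from compound 3 in one place: hydrogen in place of methyl on a saturated ring carbon. Going by the values given here, none of the measured steps touches the five-membered non-aromatic ring with 1 nitrogen, so no step gives a direct guide to this change. A single carbon leaving from a saturated ring carbon, with no donor or acceptor involved, is the kind of change that often moves the number little. Compound 4 is therefore expected to stay close to compound 3, with the step of a 1.5-fold higher number from compound 3 to compound 4 (0.18 log units; within the scatter) estimated to fall within the scatter. The estimate for compound 4 is 0.3 nM, within a range from 0.1 nM to 1 nM.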

Compound 4, half-maximal inhibitory concentration: 0.2 nM
Compound 4: middle estimate off by 1.5-fold (0.18 log units), on the high side, and the stated range covers the measured number.
By their numbers in this assay, from the lowest: compounds 1, 3 and 4 (each within the scatter of the next); then compound 2.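

In this assay, replacing the methyl on the saturated ring carbon with hydrogen gives no change at the digits printed from compound 3 to compound 4 (within the scatter), so compound 3 does not need this methyl to keep its low number. This is the only step shown that touches the five-membered non-aromatic ring with 1 nitrogen, and it adds a second kind of change to the hydroxy-for-fluoro step: here, one carbon leaves the side chain and the read-out holds. Nothing available explains why the number stays put at this position.

Still open, from the compounds shown here alone, is whether a larger group on this ring carbon, such as an ethyl, a hydroxymethyl or a dimethylamino group, would also keep the number this low. Going by these compounds, it is also open whether removing the methyl would have the same outcome with the fluoro group of compound 2 in place of the hydroxy.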